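Amide aryl swap to pyridin-4-yl: lipophilicity notes

The source may hold more compounds than are shown below. What is called first, only, known or untested is meant among the compounds shown, and "the series" means these compounds.

The series shares one core and varies the group on the amide nitrogen. Compound 1 `COc1ccc2nc(C)cc(OCC(=O)Nc3cccc(C)c3)c2c1` gives 4.83 in a physicochemical assay for lipophilicity, read by HPLC, in phosphate buffer, measured as chromatographic lipophilicity, at pH 7.4; on this read-out lower numbers stand for lower lipophilicity and higher numbers for higher lipophilicity. Compound 2 `COc1ccc2nc(C)cc(OCC(=O)Nc3c(C)cccc3C)c2c1` gives 4.55 in this assay, and compound 3 `COc1ccc2nc(C)cc(OCC(=O)Nc3ccc(Cl)cc3)c2c1` gives 5.15 in this assay, the highest of the three measured numbers. The steps of a number 0.32 log units higher from compound 1 to compound 3 (beyond the scatter) and a number 0.60 log units higher from compound 2 to compound 3 (beyond the scatter) are modest and beyond the scatter, while a number 0.28 log units lower from compound 1 to compound 2 (within the scatter) lies within it. Compound 4 `COc1ccc2nc(C)cc(OCC(=O)Nc3ccncc3)c2c1` carries pyridin-4-yl in place of 4-chlorophenyl on an amide-type nitrogen. Going by the values given here, no measured step exchanges a carbon-only ring for one bearing a hetero atom, so the measured steps give only a scale of modest moves for ring changes; a clearly larger drop is expected here, given that compound 3 stands at 5.15. Compound 4 is therefore estimated at 3.5 (range 2.9 to 4.1), an expected step of a number 1.65 log units lower from compound 3 to compound 4 (beyond the scatter).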

Compound 4, distribution coefficient: 2.5
Beside the measured number, compound 4's estimate is 1.00 log units above it; measured number below the stated range.
By their numbers in this assay, from the lowest: compound 4; then compounds 2 and 1 (each within the scatter of the next); then compound 3.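

On the amide-type nitrogen, replacing a carbon-only aromatic ring with pyridin-4-yl produces large drops in this assay: a number 2.65 log units lower from compound 3 to compound 4 (beyond the scatter), a number 2.05 log units lower from compound 2 to compound 4 (beyond the scatter) and a number 2.33 log units lower from compound 1 to compound 4 (beyond the scatter). The steps among compounds 1, 2 and 3 were modest at most, so this exchange moves the number further than any change among the carbon-only rings shown. No evidence on hand accounts for the size of these drops.

From the compounds shown here alone, whether pyridin-3-yl, pyrimidin-5-yl or 4-aminophenyl on the same nitrogen would give a similarly low number remains open. So does whether the pyridin-4-yl exchange keeps its size on a different core.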